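Adding a Further Methoxy Group to the Ketone Aryl Ring

The compounds below may be only part of what the source reports. "The series", "measured", "known", "first", "only" and "open" are said of these compounds alone.

Compound 1 `COc1cc(-c2cc(/C=C/C(=O)c3ccc(Cl)c(Cl)c3)[nH]n2)cc(OC)c1OC`: 79600 nM in a functional assay on SW-620 cells (Homo sapiens) for inhibition, read by sulforhodamine B assay, with a stated time of 48 h; a lower number here means a stronger inhibitor of growth, a higher number a weaker inhibitor of growth
Compound 2 `COc1ccc(C(=O)/C=C/c2cc(-c3cc(OC)c(OC)c(OC)c3)n[nH]2)cc1OC`: 2990 nM in this assay

Going by the values given here, compound 2 stands lowest of the two numbers in this assay, and the single measured step, a 27-fold lower number from compound 1 to compound 2 (1.43 log units; beyond the scatter), is large. Compound 3 `COc1cc(C(=O)/C=C/c2cc(-c3cc(OC)c(OC)c(OC)c3)n[nH]2)cc(OC)c1OC` differs from compound 2 by methoxy in place of hydrogen on an aromatic carbon. Among the compounds with values here, this change sits on the same ring as the measured step but is a different kind of change, so no measured step speaks to it directly. The expected step of a 1.2-fold lower number from compound 2 to compound 3 (0.08 log units; within the scatter) is therefore none beyond the scatter. Compound 3 is estimated at 2500 nM, within 700 nM to 9000 nM.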

Compound 3, concentration for total growth inhibition: 3080 nM
Estimate against measurement, compound 3: 1.2-fold (0.09 log units) below; measured number inside the range.
By their numbers in this assay, from the lowest: compounds 2 and 3 (each within the scatter of the next); then compound 1.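

In this assay methoxy in place of hydrogen on this aromatic carbon, ortho to a methoxy group, gives a 1.0-fold higher number from compound 2 to compound 3 (0.01 log units; within the scatter) and so stays within the scatter. The ring bearing the carbonyl thus takes this added methoxy with no measurable difference, whereas the earlier step on the same ring, a 27-fold lower number from compound 1 to compound 2 (1.43 log units; beyond the scatter) and beyond the scatter, was large. Nothing measured here offers an explanation for this result.

At this carbon the compounds shown hold only hydrogen or methoxy. On these data alone, how an amine, a hydroxyl or a carboxylic acid would read here remains open.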